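The compounds below may be only part of what the source reports. "The series", "measured", "known", "first", "only" and "open" are said of these compounds alone.

Compound 1 `Cc1cc(Oc2ccc(-c3ccn4c(CC5CC5)nnc4c3C(F)(F)F)cc2F)ccn1` and compound 2 `CCOCc1nnc2c(C(F)(F)F)c(-c3ccc(Oc4ccc(C)nc4C)c(F)c3)ccn12` were both measured in a functional assay on cells for positive allosteric modulation of metabotropic glutamate receptor 2 (Homo sapiens), read by scintillation counting and GTPgammaS binding, with a stated time of 30 min; on this read-out higher numbers stand for an effect only at larger amounts of compound and lower numbers for an effect already at smaller amounts. Compound 1 gives 56.2 nM, while compound 2 gives 29.5 nM; the two values lie within the usual scatter of each other, so the numbers show no difference between them, and compound 1 simply has the higher of the two numbers recorded. Compound 3 `CC(C)Nc1ccc(-c2ccn3c(CC4CC4)nnc3c2C(F)(F)F)cc1F` has not yet been measured in this assay. Compared with compound 1, it carries isopropylamino in place of (2-methylpyridin-4-yl)oxy on an aromatic carbon, a replacement of a two-ring aryl ether arm by a short branched amine at the same aromatic carbon. Within the data shown here, no single-point step between measured compounds is available to calibrate such a change, so the expectation rests on the structural change alone. The step from compound 1 to compound 3 is estimated as a 5.7-fold higher number from compound 1 to compound 3 (0.76 log units; beyond the scatter), a move toward a larger number beyond the scatter. Compound 3 is expected to give 320 nM, with a range from 60 nM to 2000 nM.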

Compound 3, half-maximal effective concentration: 93.3 nM
Compound 3: the middle estimate sits 3.4-fold (0.54 log units) above what was measured; the measured number falls inside the stated range.
By their numbers in this assay, from the lowest: compounds 2, 1 and 3 (each within the scatter of the next, the first and the last beyond it).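

In this assay, putting isopropylamino in place of (2-methylpyridin-4-yl)oxy on this aromatic carbon, ortho to a fluoro group, gives a step that stays within the scatter (a 1.7-fold higher number from compound 1 to compound 3 (0.22 log units; within the scatter)). On this pair, then, the six-membered aromatic ring and ether oxygen of the leaving group are not needed for a value in this range: a group with no ring, fewer heavy atoms and a hydrogen-bond donor reads the same as far as this assay can tell. No measurement shown explains why the two groups read alike.

Still open, on these data alone, is whether a cyclic amine such as morpholine, a smaller methylamino group or a longer alkylamino chain at this carbon would stay within the same range. Also open, as far as these compounds go, is whether isopropylamino would read the same on the core of compound 2.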